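This account rests on a few compounds, and the source may have more. Where it says the series, first, only, none or still open, it means among the compounds named here.

Measured compounds:
compound 2 `NC1=NC2(CCOCC2)N(OCCCOc2ccc(Cl)cc2)C(N)=N1` — 33.6 nM
compound 1 `NC1=NC2(CCSCC2)N(OCCCOc2cccc(Cl)c2Cl)C(N)=N1` — "not determined" (no result reported)

Among the measured compounds shown here, in an assay on isolated protein for inhibition of Dihydrofolate reductase (Homo sapiens), read by spectrophotometry, using NADPH, with stated times of 5 s and 6 min (a lower number here means a stronger inhibitor, a higher number a weaker inhibitor), compound 2 gives 33.6 nM, the only number reported; compound 1 carries no result in this assay, so compound 2 stands alone and no step between measured compounds can be drawn. Compound 3 `COc1ccc(OCCCON2C(N)=NC(N)=NC23CCOCC3)cc1` has not yet been measured. It differs from compound 2 in one place: methoxy in place of chloro on an aromatic carbon. For the measured compounds named here, with no measured step of this kind to lean on, only a loose expectation is possible. The chloro to methoxy exchange at this position is expected to cost some potency, with a step from compound 2 to compound 3 of a 2.4-fold higher number from compound 2 to compound 3 (0.38 log units; beyond the scatter) that is estimated to lie modestly beyond the usual scatter, though a result within the scatter would not surprise. Compound 3 is therefore expected to reach about 80 nM in this assay, within a range of 30 nM to 250 nM.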

Compound 3, half-maximal inhibitory concentration: 11.1 nM
Compound 3: middle estimate off by 7.2-fold (0.86 log units), on the high side; the whole stated range lies above it.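

In this assay, among the compounds shown here, the exchange of chloro for methoxy on the six-membered aromatic ring, para to a large group, gives a 3.0-fold lower number from compound 2 to compound 3 (0.48 log units; beyond the scatter), the first step that can be read in this set. It shows that this place accepts the 4-methoxyphenyl group in place of the 4-chlorophenyl group with a gain in potency beyond the scatter, so chloro is not required here for strong inhibition. Nothing measured here accounts for the size or direction of this step.

As far as these compounds go, whether the gain is particular to methoxy, or would also appear with an ethoxy group, a hydroxyl or an amine at this place, stays open. From the compounds shown here alone, compound 1 has no result, so what its other substitution on the aromatic ring and its different core do to potency also stays open.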